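Swapping cyclohexyl for benzyl on a sulfonylurea tail

The compounds below may be only part of what the source reports. "The series", "measured", "known", "first", "only" and "open" are said of these compounds alone.

Three compounds sharing one core were tested in a functional assay on the whole organism (blood, strain Wistar albino) for inhibition, with Rattus norvegicus as the target, read by colorimetric assay, with stated times of 15 min and 90 min, at a dose of 20 mg/kg by the oral route; a lower number here means less inhibition, a higher number more inhibition at the dose given (going by the name of the read-out). Compound 1 `Cc1ccc(-c2ccc(=O)n(-c3ccc(S(=O)(=O)NC(=O)NC4CCCCC4)cc3)n2)cc1` gives 110%. Compound 2 `Cc1ccc(-c2ccc(=O)n(-c3ccc(S(=O)(=O)NC(=O)NCc4ccccc4)cc3)n2)cc1` gives 119%, and compound 3 `O=C(NC1CCCCC1)NS(=O)(=O)c1ccc(-n2nc(-c3ccc(Cl)cc3)ccc2=O)cc1` gives 114%. The change from compound 1 to compound 2 is benzyl in place of cyclohexyl on an amide-type nitrogen, and it gave a number 9 percentage points higher from compound 1 to compound 2 (within the scatter). The cores of compound 1 and compound 3 differ by chloro in place of methyl on an aromatic carbon, with a number 4 percentage points higher from compound 1 to compound 3 (within the scatter).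

Compound 4 `O=C(NCc1ccccc1)NS(=O)(=O)c1ccc(-n2nc(-c3ccc(Cl)cc3)ccc2=O)cc1` has not yet been measured in this assay. It differs from compound 3 by benzyl in place of cyclohexyl on an amide-type nitrogen, the same change as from compound 1 to compound 2, made at the same place. Because the earlier step was a number 9 percentage points higher from compound 1 to compound 2 (within the scatter), the step from compound 3 to compound 4 is expected to be about a number 6 percentage points higher from compound 3 to compound 4 (within the scatter), resting on that single precedent. Compound 4 is therefore estimated to give about 120%, between 105% and 135%.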

Compound 4, a percentage reported as inhibition, in the whole organism at one dose (the size of the read-out at that dose, not a potency): 111%
For compound 4 the middle estimate is 9 percentage points above the measured one; the measured number falls inside the stated range.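

On the core of compound 3, benzyl in place of cyclohexyl gave a number 3 percentage points lower from compound 3 to compound 4 (within the scatter) in this assay, and with benzyl in place, chloro in place of methyl gave a number 8 percentage points lower from compound 2 to compound 4 (within the scatter). The benzyl change shows no difference between the two cores that stands clear of the usual scatter: the same change on two cores in this assay, a number 9 percentage points higher (within the scatter) from compound 1 to compound 2 and a number 3 percentage points lower (within the scatter) from compound 3 to compound 4, 12 percentage points apart, within the scatter of two such steps. The same holds for chloro in place of methyl, so these compounds show neither that a step carries over from one core to another nor that it fails to: the same change on two cores in this assay, a number 4 percentage points higher (within the scatter) from compound 1 to compound 3 and a number 8 percentage points lower (within the scatter) from compound 2 to compound 4, 12 percentage points apart, within the scatter of two such steps.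

Going by these compounds, it remains open whether an amine or a carboxylic acid in place of the chloro, or a longer chain in place of the benzyl, would move the inhibition beyond the scatter. On these data alone, each number also describes a single dose, so differences in potency remain unknown.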